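A bromophenyl in place of the methoxyphenyl

The source may report more compounds than this note shows. Statements on the series, on what has been measured and on what is new or still open speak of the compounds shown alone.

Compound 1 `COc1ccc(C2OC(c3cc(OC)c(OC)c(OC)c3)=NN2C(C)=O)cc1`: 57000 nM
Compound 2 `COc1cccc(C2OC(c3cc(OC)c(OC)c(OC)c3)=NN2C(C)=O)c1`: 45000 nM

In a functional assay on L1210 cells (Mus musculus) for antiproliferative activity, read by MTT assay, with a stated time of 72 h (a lower number here means a stronger inhibitor, a higher number a weaker inhibitor), compound 1 gives 57000 nM, the highest of the two numbers; its nearest neighbour is compound 2, with a 1.3-fold lower number from compound 1 to compound 2 (0.10 log units; within the scatter). Compound 3 `COc1cc(C2=NN(C(C)=O)C(c3cccc(Br)c3)O2)cc(OC)c1OC` differs from compound 1 by 3-bromophenyl in place of 4-methoxyphenyl on a saturated ring carbon. Among the compounds with values here, the only measured step, a 1.3-fold lower number from compound 1 to compound 2 (0.10 log units; within the scatter), moved the methoxy group around the ring and stayed within the scatter; no measured step exchanges a methoxy for a bromine. With nothing to point elsewhere, compound 3 is expected to sit close to compound 1, with an estimated 1.4-fold lower number from compound 1 to compound 3 (0.15 log units; within the scatter). The estimate for compound 3 is therefore 40000 nM, expected between 12000 nM and 130000 nM.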

Compound 3, half-maximal inhibitory concentration: 600 nM
Estimate against measurement, compound 3: 67-fold (1.82 log units) above, and the stated range ends above it.
By their numbers in this assay, from the lowest: compound 3; then compounds 2 and 1 (each within the scatter of the next).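

The aromatic ring on the saturated ring carbon can strongly change the number, which moving the methoxy group gave no sign of. With the place on that ring unchanged, bromo in place of methoxy gives a 75-fold lower number from compound 2 to compound 3 (1.88 log units; beyond the scatter) and is thus not tied to compound 1 alone, since 3-bromophenyl in place of 4-methoxyphenyl gives a 95-fold lower number from compound 1 to compound 3 (1.98 log units; beyond the scatter) as well. Nothing measured here explains this drop. Still open, from the compounds shown here alone, is whether chloro, an amine or a carboxylic acid in place of the bromo would keep so low a number, and whether bromo would do so elsewhere on that aromatic ring.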